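Notes on the aryl-to-iodo step at the fused ring

The source may hold more compounds than are shown below. What is called first, only, known or untested is meant among the compounds shown, and "the series" means these compounds.

Measured compounds:
compound 1 `CN(C)CCCC1(c2ccc(F)cc2)OCc2cc(-c3ccccc3)ccc21`: 1800 nM
compound 2 `CN(C)CCCC1(c2ccc(F)cc2)OCc2cc(CCc3ccccc3)ccc21`: "not determined" (no result reported)
compound 3 `CN(C)CCCC1(c2ccc(F)cc2)OCc2cc(-c3cccc(F)c3)ccc21`: "not determined" (no result reported)

Going by the values given here, in an assay on Caudate-putamen for displacement of a labelled ligand from sodium-dependent dopamine transporter (Rattus norvegicus), read by scintillation counting (on this read-out higher numbers stand for weaker inhibition and lower numbers for stronger inhibition), compound 1 gives 1800 nM and is the only compound of the series with a number. Compound 2 stands at "not determined" (no result reported) in this assay. Among the compounds with values here, compound 3 likewise stands at "not determined" (no result reported) in this assay, so it has no number to compare against compound 1, and no step between measured compounds can be stated.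

The next compound, compound 4 `CN(C)CCCC1(c2ccc(F)cc2)OCc2cc(I)ccc21`, arises from compound 3 by the change (iodo in place of 3-fluorophenyl on an aromatic carbon). Within the data shown here, with no measured step on record, the direction of this change in this assay cannot be read from the data; the one anchor is compound 1 at 1800 nM, which sets the region in which the series has so far been found. A shift of moderate size in either direction would not surprise, and a result within the scatter of that anchor is equally possible. Compound 4 is expected at about 800 nM, with the likely range running from 150 nM to 4000 nM.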

Compound 4, inhibition constant: 1350 nM
Beside the measured number, compound 4's estimate is 1.7-fold (0.23 log units) below it, and the stated range covers the measured number.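

In this assay the series now has its first readable step, a 1.3-fold lower number from compound 1 to compound 4 (0.12 log units; within the scatter), and it lies within the scatter. Going by these compounds alone, at this aromatic carbon, para to a fused ring, the six-membered aromatic ring of the phenyl can thus give way to iodo, a group with no ring, without a step beyond the scatter, something the earlier compounds could not show. No supporting data bear on why this pair reads alike.

Steps involving compound 2 and compound 3 cannot be read, as neither has a number, so the effect of a substituted phenyl or a two-carbon link at this position stays unknown. Also open, going by these compounds, is whether bromo, chloro, an amine or a carboxylic acid on this same carbon would stay within the scatter of these two values in this assay.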